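Styryl sulfone series: swapping the anilino ester for an acid

This account rests on a few compounds, and the source may have more. Where it says the series, first, only, none or still open, it means among the compounds named here.

Measured compounds and their values:
- Compound 1 `COc1ccc(CS(=O)(=O)/C=C/c2c(OC)cc(OCCCC(=O)O)cc2OC)cc1N` — 20000 nM
- Compound 2 `COc1cc(OC)c(/C=C/S(=O)(=O)Cc2ccc(Cl)c(N)c2)c(OC)c1` — 10 nM
- Compound 3 `COC(=O)C(Nc1cc(CS(=O)(=O)/C=C/c2c(OC)cc(OC)cc2OC)ccc1OC)c1ccccc1` — 30 nM

In a functional assay on K562 cells (Homo sapiens) for cytotoxicity, read by trypan blue exclusion, with a stated time of 96 h (on this read-out lower numbers stand for stronger inhibition and higher numbers for weaker inhibition), compound 3 gives 30 nM. Among the three numbers it stands second highest: its nearest neighbour is compound 2, whose number is lower and whose gap to compound 3 lies beyond the scatter; the furthest is compound 1, whose number is far higher, also beyond the scatter. Compound 3 thus sits closer to the potent end of the series than to its weak end.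

Compound 4 `COc1cc(OC)c(/C=C/S(=O)(=O)Cc2ccc(OC)c(NC(C(=O)O)c3ccc(Br)cc3)c2)c(OC)c1` is yet to be measured in this assay. It differs from compound 3 in one place: (4-bromophenyl)(carboxy)methyl in place of methoxycarbonyl)(benzyl on a nitrogen on an aromatic ring. The ester carbonyl of compound 3 becomes a free carboxylic acid, and a bromine is added to the phenyl ring.

Among the measured compounds shown here, no step between measured compounds shows this change. For the measured compounds named here, the only measured compound carrying a free carboxylic acid, compound 1, gives the highest number of the three, though its acid sits in a different place, so the parallel is loose. A moderate step toward a higher number is expected, a 3.3-fold higher number from compound 3 to compound 4 (0.52 log units; beyond the scatter), not a collapse. Compound 4 is estimated at 100 nM, within the range 30 nM to 400 nM.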

Compound 4, half-maximal inhibitory concentration: 200 nM
For compound 4 the middle estimate is 2.0-fold (0.30 log units) below the measured one; the measured number falls inside the stated range.
By their numbers in this assay, from the lowest: compound 2; then compound 3; then compound 4; then compound 1.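

In this assay, the group on a nitrogen on an aromatic ring now has its first readable step: (4-bromophenyl)(carboxy)methyl in place of methoxycarbonyl)(benzyl gives a 6.7-fold higher number from compound 3 to compound 4 (0.82 log units; beyond the scatter), a loss beyond the scatter but a modest one, so this position accepts a free carboxylic acid and a bromine on the phenyl ring together without an outright loss of cytotoxicity, with compound 4 still at 200 nM. The step carries two edits at once, the ester becoming an acid and the bromine being added, and its size cannot be divided between them. Nothing measured here accounts for the rise in the number.

The compounds shown leave open which edit drives the step, since neither the unsubstituted phenyl acid nor the 4-bromophenyl methyl ester stands among them to separate the two. Also open, on these data alone, is how the position responds to a primary amide in place of the acid or to a fluorine in place of the bromine, either of which would show how much of the step follows the acid and how much follows the halogen.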